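The source may hold more compounds than are shown below. What is called first, only, known or untested is meant among the compounds shown, and "the series" means these compounds.

In a physicochemical assay for lipophilicity, measured as octanol-water partition (on this read-out lower numbers stand for lower lipophilicity and higher numbers for higher lipophilicity), compound 1 `N#Cc1c(-c2ccco2)[n+]([O-])c2ccc(F)cc2[n+]1[O-]` gives 0.983, compound 2 `N#Cc1c(-c2ccco2)[n+]([O-])c2ccc(Cl)cc2[n+]1[O-]` gives 1.11, and compound 3 `COc1ccc2c(c1)[n+]([O-])c(C#N)c(-c1ccco1)[n+]2[O-]` gives 0.354. The number of compound 2 is the highest of the three shown, although the step of a number 0.13 log units higher from compound 1 to compound 2 (within the scatter) is within the scatter and so does not set compound 2 apart from compound 1; the step of a number 0.76 log units lower from compound 2 to compound 3 (beyond the scatter), by contrast, lies beyond the scatter, as does a number 0.63 log units lower from compound 1 to compound 3 (beyond the scatter). Compound 4 `Cc1ccc(-c2c(C#N)[n+]([O-])c3cc(Cl)ccc3[n+]2[O-])cc1` differs from compound 2 at a single place: 4-methylphenyl in place of furan-2-yl on an aromatic carbon. None of the three measured steps bears on this change, as each of them exchanges one group of one heavy atom for another on the fused ring system, whereas here a five-membered aromatic ring with one hetero atom and one hydrogen-bond acceptor leaves and a six-membered ring of carbon only with no acceptor enters. For the measured compounds named here, with no measured step of this kind available, the expectation rests on the shift in what is counted alone, and on that basis compound 4 is expected to give a number in this assay that is higher than that of compound 2, with a step of a number 1.19 log units higher from compound 2 to compound 4 (beyond the scatter) expected and well beyond the scatter. Compound 4 is therefore estimated at 2.3, with a range from 1.7 to 2.9.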

Compound 4, partition coefficient: 2.6
Estimate against measurement, compound 4: 0.30 log units below, and the stated range covers the measured number.
By their numbers in this assay, from the lowest: compound 3; then compounds 1 and 2 (each within the scatter of the next); then compound 4.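

In this assay, for the compounds shown here, the exchange of furan-2-yl for 4-methylphenyl gives a number 1.49 log units higher from compound 2 to compound 4 (beyond the scatter), showing for the first time that the aromatic carbon next to the ring nitrogen and ortho to a cyano group is a place where a single change moves this read-out substantially. This step is larger than a number 0.76 log units lower from compound 2 to compound 3 (beyond the scatter), the largest of the steps seen earlier, all of which exchange one small group for another elsewhere on the shared core, so among the one-place changes shown the largest is this exchange of one aromatic ring for another. Nothing in the data accounts for the size of this step.

The compounds shown cannot separate what the six-membered ring of carbon contributes from what its methyl group contributes, and it remains open how a plain phenyl, a thiophene or a pyridine ring, or a group such as an amine or a carboxylic acid, would read at this position. On these data alone, it also remains open whether the step would have the same size with fluoro or methoxy in place of the chloro on the core, since this exchange is seen only once, between compound 2 and compound 4.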